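Ester Chain Extension on a Diaryl Ether Nitrile Scaffold

This account rests on a few compounds, and the source may have more. Where it says the series, first, only, none or still open, it means among the compounds named here.

Of the compounds shown here, two of one series have been measured so far. Compound 1 `Cc1cc(CCC#N)cc(C)c1Oc1cc(Nc2ccc(C#N)cc2)c(N)cc1C(=O)NC1CC1` carries a cyclopropylcarbamoyl group on the central ring, and in a physicochemical assay for solubility, read by HPLC, in phosphate buffer, with a stated time of 4 h, at pH 7.4, tested at 10 mg/mL (on this read-out lower numbers stand for lower solubility and higher numbers for higher solubility), compound 1 gives 1.94 ug/mL. Compound 2 `CC(=O)OCc1cc(N)c(Nc2ccc(C#N)cc2)cc1Oc1c(C)cc(CCC#N)cc1C` carries an acetoxymethyl group at that position instead, and in this assay compound 2 gives 1.86 ug/mL. For the measured compounds named here, the single measured step, a 1.0-fold lower number from compound 1 to compound 2 (0.02 log units; within the scatter), shows that exchanging the carbamoyl for the ester left the read-out essentially unchanged. Compound 2 therefore stands at the lower of the two numbers, though its gap to compound 1 is within the scatter, so no order between them can be claimed.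

Compound 3 `Cc1cc(CCC#N)cc(C)c1Oc1cc(Nc2ccc(C#N)cc2)c(N)cc1COC(=O)C1CC1` differs from compound 2 by cyclopropyl in place of methyl on a carbonyl carbon. Going by the values given here, no measured step touches this carbonyl position, so nothing recorded speaks directly to the change; the one step seen so far was flat, and the ester is retained. On that basis compound 3 is expected to show at most a small shift, a 1.2-fold lower number from compound 2 to compound 3 (0.09 log units; within the scatter), likely no further than the scatter. The estimate for compound 3 is 1.5 ug/mL, with a range from 0.7 ug/mL to 3.5 ug/mL.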

Compound 3, solubility: 1.64 ug/mL
For compound 3 the middle estimate is 1.1-fold (0.04 log units) below the measured one; low and high end bracket the measured number.
By their numbers in this assay, from the lowest: compounds 3, 2 and 1 (each within the scatter of the next).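

The carbonyl position now has a step of its own: a 1.1-fold lower number from compound 2 to compound 3 (0.05 log units; within the scatter) in this assay, so a three-membered carbon ring in place of methyl on the carbonyl carbon stays within the scatter, although it brings in more heavy atoms than it removes. The second step gives the same kind of result for the larger exchange on the aromatic carbon, where a 1.2-fold lower number from compound 1 to compound 3 (0.07 log units; within the scatter) also stays within the scatter, so that compound 3 cannot be told apart from either compound 1 or compound 2 on this read-out, and the cyclopropyl can sit on either side of the linking group without a step beyond the scatter. No evidence at hand accounts for these readings.

The compounds shown leave open whether any group on this carbonyl carbon, such as a longer chain or an amine, would give a step beyond the scatter. They also leave open what a carboxylic acid on the aromatic carbon, in place of the ester or the amide, would read in this assay.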